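This account rests on a few compounds, and the source may have more. Where it says the series, first, only, none or still open, it means among the compounds named here.

Compound 1 `CNC(=O)c1ccncc1Nc1cc(-c2ccc3ccn(C)c3c2)c2nccnc2c1` is the starting point. In an ADME assay on microsomes from liver (Mus musculus, strain CD-1) for metabolic stability, read by LC-MS, tested at 2 uM (a lower number here means that the compound disappears faster, a higher number that the compound lasts longer), compound 1 gives 0.45 h, the higher of the two plain numbers shown. Compound 2 `CC(=O)N1CCOC(CNC(=O)c2ccncc2Nc2cc(-c3ccc4ccn(C)c4c3)c3nccnc3c2)C1` gives 0.217 h in this assay, and the step of a 2.1-fold lower number from compound 1 to compound 2 (0.32 log units; beyond the scatter). Compound 3 `CN1CC(NC(=O)c2ccncc2Nc2cc(-c3ccc4ccn(C)c4c3)c3nccnc3c2)C1` reaches only a limit of this assay, > 1 h. That limit of > 1 h in this assay, at which 1 of the 3 values shown sits, still marks the step of an at least 2.2-fold higher number from compound 1 to compound 3 (0.34 log units; beyond the scatter), and from compound 2 the step of an at least 4.6-fold higher number from compound 2 to compound 3 (0.66 log units; beyond the scatter).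

Compound 4 `CN1CCC(N(C)C(=O)c2ccncc2Nc2cc(-c3ccc4ccn(C)c4c3)c3nccnc3c2)C1` differs from compound 1 by 1-methylpyrrolidin-3-yl in place of hydrogen on an amide-type nitrogen, the new group sitting on an amide-type nitrogen whose other neighbours are a carbonyl carbon and a saturated chain carbon. The closest measured change is the step of an at least 2.2-fold higher number from compound 1 to compound 3 (0.34 log units; beyond the scatter), where 1-methylazetidin-3-yl entered on an amide-type nitrogen. The step of a 2.1-fold lower number from compound 1 to compound 2 (0.32 log units; beyond the scatter) went the other way, but with a different group. On that basis the step is expected to be upward: a 2.0-fold higher number from compound 1 to compound 4 (0.30 log units; within the scatter). The estimated value of compound 4 in this assay is 0.9 h, likely between 0.4 h and 2 h.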

Compound 4, half-life: > 1 h
Compound 4 gave a limit, no number; the forecaster's own chance of this, stated with the estimate: 40%; middle value at least 1.1-fold (0.04 log units) from the limit.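

In this assay compound 4 reaches only a limit, > 1 h, and is the second compound to stop there: the limit of > 1 h in this assay, at which 2 of the 4 values shown sit. The rise in this half-life is thus not confined to 1-methylazetidin-3-yl, as 1-methylpyrrolidin-3-yl on the amide-type nitrogen, which here also keeps its methyl, gives an at least 2.2-fold higher number from compound 1 to compound 4 (0.34 log units; beyond the scatter). For the compounds shown here, the same group also gives an at least 4.6-fold higher number from compound 2 to compound 4 (0.66 log units; beyond the scatter), and compound 2, with its 4-acetylmorpholin-2-yl group, remains the one compound that goes against the upward trend.

As far as these compounds go, the step from compound 3 to compound 4 cannot be read, so the order of these two compounds and the true size of their rise stay open. From the compounds shown here alone, it is also open whether the ring nitrogen is needed, which a cyclopentyl group in the same place would test.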